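The compounds below may be only part of what the source reports. "The series", "measured", "known", "first", "only" and "open" are said of these compounds alone.

Measured so far in a functional assay on NCI-H460 cells (Homo sapiens) for cytotoxicity, read by MTT assay, with a stated time of 72 h; a higher number here means a weaker inhibitor, a lower number a stronger inhibitor:
compound 1 `COc1cc2c(Oc3ccc(NC(=O)c4nnn(-c5ccccc5C)c4C)cc3F)ccnc2cc1OCCCN1CCCCC1` gives 780 nM;
compound 2 `COc1cc2c(Oc3ccc(NC(=O)c4nnn(-c5ccc(F)cc5)c4C(F)(F)F)cc3F)ccnc2cc1OCCCN1CCCCC1` gives 190 nM;
compound 3 `COc1cc2c(Oc3ccc(NC(=O)c4nnn(-c5ccccc5C)c4C)cc3F)ccnc2cc1OCCCN1CCC(C)CC1` gives 770 nM.

Compound 1 and compound 3 differ in one place only, (methyl in place of hydrogen on a saturated ring carbon), and the step of a 1.0-fold lower number from compound 1 to compound 3 (0.01 log units; within the scatter) shows that this change left the result essentially unaltered. Compound 2 stands apart from both, with the lowest of the three numbers, and its steps to compound 1 and compound 3 lie beyond the scatter; the difference between the core of compound 2 and the core of compound 1 is not broken down here.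

Compound 4 `COc1cc2c(Oc3ccc(NC(=O)c4nnn(-c5ccc(F)cc5)c4C(F)(F)F)cc3F)ccnc2cc1OCCCN1CCC(C)CC1` has not yet been measured. It relates to compound 2 as compound 3 relates to compound 1: methyl in place of hydrogen on a saturated ring carbon, the same change at the same place. Because the earlier step of a 1.0-fold lower number from compound 1 to compound 3 (0.01 log units; within the scatter) was flat, a similarly small step is expected from compound 2 to compound 4, a 1.1-fold higher number from compound 2 to compound 4 (0.02 log units; within the scatter). Compound 4 is therefore estimated to give about 200 nM in this assay, with a likely range from 100 nM to 400 nM.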

Compound 4, half-maximal inhibitory concentration: 190 nM
Compound 4: middle estimate off by 1.1-fold (0.02 log units), on the high side; measured number inside the range.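

In this assay the change from piperidin-1-yl to 4-methylpiperidin-1-yl gave no change at the digits printed from compound 2 to compound 4 (within the scatter) and so behaved as it did on the core of compound 1: the same change on two cores in this assay, a 1.0-fold lower number (0.01 log units; within the scatter) from compound 1 to compound 3 and no change at the digits printed (within the scatter) from compound 2 to compound 4, 1.0-fold (0.01 log units) apart, within the scatter of two such steps.

On these two cores, then, adding the methyl leaves the number where it was, even though the cores differ from each other. This does not show that the change would stay flat on a third core or in any other test.

The compounds shown leave open whether a different group on the same ring carbon, such as an ethyl or a hydroxyl, would shift the number. They also leave open what a longer chain to the piperidin-1-yl group would do.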